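Replacing 2-chloroethyl with 1-(hydroxymethyl)ethenyl in compound 4

A few compounds are considered here, and "the series" means these few. Any claim that something is new, unique, unknown or untested is made for them only; others in the source may bear on it.

Measured in a functional assay on HCT-116 cells (Homo sapiens) for antiproliferative activity, read by MTT assay, with a stated time of 48 h; a higher number here means a weaker inhibitor, a lower number a stronger inhibitor:
Compound 1 `CCCCCCCCCC(CCO)n1cnc2c(Cl)ncnc21` gives 890 nM
Compound 2 `CCCCCCCCCC(CCOS(C)(=O)=O)n1cnc2c(Cl)ncnc21` gives 5440 nM
Compound 3 `CCCCCCCCCC(CCCl)n1cnc2c(Cl)ncnc21` gives 10200 nM

Compound 3 stands at the high end of these numbers, with a 1.9-fold higher number from compound 2 to compound 3 (0.27 log units; within the scatter). Compound 4 `C=C(CO)C(CCCCCCCCC)n1cnc2c(Cl)ncnc21` carries 1-(hydroxymethyl)ethenyl in place of 2-chloroethyl on a saturated chain carbon bound to an aromatic nitrogen and a saturated chain carbon. The best guide is the free hydroxy of compound 1, which returns in the new group: the measured step was large, an 11-fold higher number from compound 1 to compound 3 (1.06 log units; beyond the scatter). Capping that hydroxy was also costly, a 6.1-fold higher number from compound 1 to compound 2 (0.79 log units; beyond the scatter). Among the compounds with values here, no measured compound carries the double bond, so a somewhat smaller step in the same direction, towards a lower number, is expected: a 5.7-fold lower number from compound 3 to compound 4 (0.75 log units; beyond the scatter). Compound 4 is estimated at 1800 nM, with an expected range of 600 nM to 5500 nM.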

Compound 4, half-maximal inhibitory concentration: > 50000 nM
Compound 4 gave a limit, no number (the forecaster's own chance of this, stated with the estimate: 2%); middle value at least 27-fold (1.44 log units) from the limit.
By their numbers in this assay, from the lowest: compound 1; then compounds 2 and 3 (each within the scatter of the next). At a limit, above all of these: compound 4.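

In this assay compound 4 gives a limit, not a number: (the limit of > 50000 nM in this assay, at which 1 of the 4 values shown sits). Read as lower bounds, its steps all point the same way (an at least 4.9-fold higher number from compound 3 to compound 4 (0.69 log units; beyond the scatter); an at least 9.1-fold higher number from compound 2 to compound 4 (0.96 log units; beyond the scatter); an at least 56-fold higher number from compound 1 to compound 4 (1.74 log units; beyond the scatter)). Compounds 1 and 4 both carry a free hydroxy, yet only compound 1 keeps its activity, so at this position a hydroxy alone is not enough, and the earlier trend among compounds 1 to 3 does not extend to 1-(hydroxymethyl)ethenyl.

The compounds shown do not separate the double bond from the rest of the new group. On these data alone, how an amine or a carboxylic acid at the end of the chain would read also stays open.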